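Removing one methoxy group from an inert trio

A few compounds are considered here, and "the series" means these few. Any claim that something is new, unique, unknown or untested is made for them only; others in the source may bear on it.

Three compounds were measured in a functional assay on A549 cells (Homo sapiens) for cytotoxicity, read by sulforhodamine B assay, with a stated time of 48 h, tested at 0.01 uM; a lower number here means a stronger effect, a higher number a weaker effect of the compound at the concentration tested:

Compound 1, `COc1cc(-c2cc(/C=C/C(=O)c3ccc(N)cc3)[nH]n2)cc(OC)c1OC`: 96%
Compound 2, `COc1cc(-c2cc(/C=C/C(=O)c3ccc(Cl)c(Cl)c3)[nH]n2)cc(OC)c1OC`: 101%
Compound 3, `COc1ccc(C(=O)/C=C/c2cc(-c3cc(OC)c(OC)c(OC)c3)n[nH]2)cc1OC`: 98%

All three share a core and differ only in the aryl group on the carbonyl carbon. Compound 3 stands second highest of the three numbers. Its nearest neighbour is compound 1, separated by a number 2 percentage points higher from compound 1 to compound 3 (within the scatter), and the furthest is compound 2, separated by a number 3 percentage points lower from compound 2 to compound 3 (within the scatter). The remaining step, a number 5 percentage points higher from compound 1 to compound 2 (within the scatter), is likewise within the scatter, so none of the three compounds can be called more or less active than another at this concentration.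

Compound 4, `COc1ccc(C(=O)/C=C/c2cc(-c3cc(OC)c(OC)c(OC)c3)n[nH]2)cc1`, has not yet been measured. It differs from compound 3 by hydrogen in place of methoxy on an aromatic carbon.

Going by the values given here, no measured step removes a methoxy group; the closest comparison is a number 3 percentage points lower from compound 2 to compound 3 (within the scatter), where the dimethoxyphenyl group enters on the carbonyl carbon without a change beyond the scatter. Since every change of the aryl group on the carbonyl carbon so far, including a number 5 percentage points higher from compound 1 to compound 2 (within the scatter), left the number where it was, the expected step is no change at the digits printed from compound 3 to compound 4 (within the scatter), none beyond the scatter. The estimate for compound 4 in this assay is therefore 98%, with a range from 89% to 107%.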

Compound 4, a percentage reported as activity, at one concentration (the size of the read-out at that concentration, not a potency): 98%
The estimate for compound 4 equals the measured number at the digits printed, and the stated range covers the measured number.
By their numbers in this assay, from the lowest: compounds 1, 3, 4 and 2 (each within the scatter of the next).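

In this assay, the removal of one methoxy group, turning 3,4-dimethoxyphenyl into 4-methoxyphenyl, puts hydrogen on an aromatic carbon ortho to a methoxy group and meta to a large group, and the result is no change at the digits printed from compound 3 to compound 4 (within the scatter). Going by these compounds alone, this is the first direct reading at this position, where the earlier compounds only exchanged whole aryl groups, and the new aryl group also stays level with the other two: the comparison with the dichlorinated compound gives a number 3 percentage points lower from compound 2 to compound 4 (within the scatter), and the comparison with the amino compound gives a number 2 percentage points higher from compound 1 to compound 4 (within the scatter). All four aryl groups on the carbonyl carbon thus remain inseparable at this concentration, and no independent measurement bears on this result.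

With every number this close at one low concentration, the compounds shown leave open whether this position matters at all under conditions where the series shows an effect. They also leave open whether a hydroxy group, a carboxylic acid or a longer alkoxy chain on this aromatic carbon would move the number beyond the scatter.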